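The source may report more compounds than this note shows. Statements on the series, on what has been measured and on what is new or still open speak of the compounds shown alone.

Measured so far in a functional assay on HeLa cells (Homo sapiens) for cytotoxicity, with a stated time of 72 h; on this read-out higher numbers stand for weaker inhibition and lower numbers for stronger inhibition:
compound 1 `CCCC#Cc1cn([C@@H]2O[C@H](CO)[C@@H](O)[C@H](O)[C@H]2O)c(=O)nc1N` — 191000 nM
compound 2 `Nc1nc(=O)n([C@@H]2O[C@H](CO)[C@@H](O)[C@H](O)[C@H]2O)cc1C#Cc1ccccc1` — 201000 nM
compound 3 `CCCCCc1ccc(C#Cc2cn([C@@H]3O[C@H](CO)[C@@H](O)[C@H](O)[C@H]3O)c(=O)nc2N)cc1` — 43000 nM

Compound 2 gives the highest number of the three; compound 1 sits within the scatter of it, while compound 3 lies further off. Compound 4 `C#Cc1cn([C@@H]2O[C@H](CO)[C@@H](O)[C@H](O)[C@H]2O)c(=O)nc1N` is not yet measured. It differs from compound 2 by hydrogen in place of phenyl on a triple-bonded carbon. The bearing step is a 1.1-fold higher number from compound 1 to compound 2 (0.02 log units; within the scatter), which shows that swapping one group for another on the triple-bonded carbon changed little; a 4.7-fold lower number from compound 2 to compound 3 (0.67 log units; beyond the scatter) shows that adding more at that end lowered the number. Removing the group entirely may therefore push the number up, though only modestly; the expected step is a 1.6-fold higher number from compound 2 to compound 4 (0.20 log units; within the scatter). For compound 4 in this assay the estimate is 320000 nM, within 160000 nM to 650000 nM.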

Compound 4, half-maximal inhibitory concentration: >= 250000 nM
Compound 4 gave a limit, no number (the forecaster's own chance of this, stated with the estimate: 25%); the middle value is on the limit's open side.
By their numbers in this assay, from the lowest: compound 3; then compounds 1 and 2 (each within the scatter of the next). At a limit, above all of these: compound 4.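

In this assay compound 4 gives no number, only a limit: the limit of >= 250000 nM in this assay, at which 1 of the 4 values shown sits. The steps read an at least 1.2-fold higher number from compound 2 to compound 4 (0.09 log units; that floor lies within the scatter) and an at least 1.3-fold higher number from compound 1 to compound 4 (0.11 log units; that floor lies within the scatter), so the size of the change on removing phenyl or propyl stays unfixed. Hydrogen on the triple-bonded carbon gives no lower number than either group, so nothing here shows that removing the group lowers the number.

Still open, on these data alone, is how far compound 4 lies past its limit. Also open, as far as these compounds go, is whether an amine or a longer chain in place of pentyl in compound 3 lowers the number further.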